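Swapping Bromo for Chloro on a Five-Ring Indoline Core

The compounds below may be only part of what the source reports. "The series", "measured", "known", "first", "only" and "open" are said of these compounds alone.

Measured compounds:
Compound 1 `COC(=O)[C@@]1(C)CCC=C2[C@@H]1CC[C@@H](C)[C@]2(C)Cc1c[nH]c2ccc(Br)cc12` gives 15000 nM in a functional assay on A549 cells (Homo sapiens) for inhibition, read by sulforhodamine B assay, with a stated time of 48 h; on this read-out higher numbers stand for weaker inhibition of growth and lower numbers for stronger inhibition of growth.
Compound 2 `COC(=O)[C@@]1(C)CCC=C2[C@@H]1CC[C@@H](C)[C@]2(C)Cc1c[nH]c2ccc(Cl)cc12` gives 16000 nM in this assay.
Compound 3 `COC(=O)[C@@]1(C)CC[C@@H]2C3=C1CC[C@@H](C)[C@]3(C)C[C@@H]1c3cc(Br)ccc3N[C@H]21` gives 40000 nM in this assay.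

Compound 2 differs from compound 1 only by chloro in place of bromo on an aromatic carbon, and that change gave a 1.1-fold higher number from compound 1 to compound 2 (0.03 log units; within the scatter). Compound 3 is built on a different core; the difference between the two cores is not broken down here. Compound 4 `COC(=O)[C@@]1(C)CC[C@@H]2C3=C1CC[C@@H](C)[C@]3(C)C[C@@H]1c3cc(Cl)ccc3N[C@H]21` is the unmeasured partner of compound 3, made by chloro in place of bromo on an aromatic carbon. This is the same kind of change as before, though here the aromatic carbon belongs to a fused or bridged system of five rings rather than two. Because compound 1 to compound 2 showed a 1.1-fold higher number from compound 1 to compound 2 (0.03 log units; within the scatter), the expected step is a 1.1-fold higher number from compound 3 to compound 4 (0.02 log units; within the scatter), essentially flat. Compound 4 is therefore estimated at 42000 nM in this assay, within 20000 nM to 90000 nM.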

Compound 4, concentration for 50% growth inhibition: 35000 nM
Estimate against measurement, compound 4: 1.2-fold (0.08 log units) above, and the stated range covers the measured number.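

In this assay, chloro in place of bromo gave a 1.1-fold lower number from compound 3 to compound 4 (0.06 log units; within the scatter), so on this core too the swap produced no readable change. Set side by side, the two steps do not differ, and the swap behaved alike on both cores: the same change on two cores in this assay, a 1.1-fold higher number (0.03 log units; within the scatter) from compound 1 to compound 2 and a 1.1-fold lower number (0.06 log units; within the scatter) from compound 3 to compound 4, 1.2-fold (0.09 log units) apart, within the scatter of two such steps. This shows only that one flat result carried over between these two cores in one assay; it does not show why, or that a change with a larger effect would carry over equally well.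

The compounds shown leave open whether the halogen matters at all, as they include neither a plain hydrogen nor a different group, such as an amine or methoxy, on that aromatic carbon. As far as these compounds go, whether such groups would behave alike on both cores also remains open.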